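The source may report more compounds than this note shows. Statements on the series, on what has been measured and on what is new or still open speak of the compounds shown alone.

Compound 1 `O=C(NCc1ccncc1)Nc1ccc(S(=O)(=O)N2CC3CCC(C2)O3)cc1`: 279 nM
Compound 2 `O=C(NCc1ccncc1)Nc1ccc(S(=O)(=O)c2ccc(Cl)cc2)cc1`: 126 nM

Going by the values given here, in an assay on isolated protein for activation of Nicotinamide phosphoribosyltransferase (Homo sapiens) (on this read-out lower numbers stand for an effect already at smaller amounts and higher numbers for an effect only at larger amounts of compound), compound 2 holds the lower of the two numbers recorded, and the only measured step, a 2.2-fold lower number from compound 1 to compound 2 (0.35 log units; beyond the scatter), separates it from compound 1. Compound 3 `CN(C1CCCC1)S(=O)(=O)c1ccc(NC(=O)NCc2ccncc2)cc1` carries cyclopentyl(methyl)amino in place of 4-chlorophenyl on a sulfonyl sulfur. The step from compound 1 to compound 2 is the one that bears on this change: there a nitrogen-containing non-aromatic group on the sulfonyl sulfur gave way to 4-chlorophenyl and the number fell modestly. Among the compounds with values here, compound 3 again places a nitrogen-containing non-aromatic group on the sulfonyl sulfur, so a modest rise in the number, roughly undoing that step, is what is expected, though the two amino groups are not the same and the single step leaves the size uncertain. For compound 3 the estimate in this assay is 250 nM, within a range from 100 nM to 700 nM. That estimate corresponds to an expected step of a 2.0-fold higher number from compound 2 to compound 3 (0.30 log units; within the scatter).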

Compound 3, half-maximal effective concentration: 123 nM
Estimate against measurement, compound 3: 2.0-fold (0.31 log units) above, within the range that was stated.
By their numbers in this assay, from the lowest: compounds 3 and 2 (each within the scatter of the next); then compound 1.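

In this assay the sulfonyl sulfur takes cyclopentyl(methyl)amino as well as 4-chlorophenyl: this exchange gives a 1.0-fold lower number from compound 2 to compound 3 (0.01 log units; within the scatter) and no difference that stands out from the scatter. A nitrogen-linked non-aromatic group at this place therefore does not in itself bring the higher number of compound 1, and the exchange between the two amino groups gives a 2.3-fold lower number from compound 1 to compound 3 (0.36 log units; beyond the scatter) and so separates them, showing that the choice of amino group matters here. Nothing measured on these compounds explains why the groups compare as they do. The compounds shown leave open whether an open-chain amine such as diethylamino would match cyclopentyl(methyl)amino on the sulfonyl sulfur. They also leave open whether plain phenyl, without the chlorine, would match 4-chlorophenyl.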